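Trading the cyclobutyl thioester for an isopropyl group

The source may hold more compounds than are shown below. What is called first, only, known or untested is meant among the compounds shown, and "the series" means these compounds.

Compound 2 `Cc1nc(S(C)(=O)=O)ccc1Oc1ncnc(OC2CCN(C(=O)SC3CCC3)CC2)c1F` is measured in a functional assay on isolated protein for inhibition of Glucose-dependent insulinotropic receptor (Rattus norvegicus), read by HTRF and cAMP accumulation (a higher number here means that more compound is needed for the effect, a lower number that less compound is needed), and gives 77.4 nM. Among the measured compounds shown here, its only neighbour is compound 1 `Cc1nc(S(C)(=O)=O)ccc1Oc1ncnc(OC2CCN(C(=O)OC3(C(F)(F)F)CCC3)CC2)c1F`, which in this assay gives 63.3 nM; the step of a 1.2-fold higher number from compound 1 to compound 2 (0.09 log units; within the scatter) lies within the scatter, so the two compounds stand together and neither can be set above the other.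

Compound 3 `Cc1nc(S(C)(=O)=O)ccc1Oc1ncnc(OC2CCN(C(=S)OC(C)C)CC2)c1F` follows from compound 2 by a group of 6 heavy atoms (4 carbon, 1 oxygen, 1 sulfur; no ring) in place of a group of 7 heavy atoms (5 carbon, 1 oxygen, 1 sulfur; one four-membered non-aromatic ring of carbon only), on an amine nitrogen in a ring; the place is on an amine nitrogen in a ring of a six-membered non-aromatic ring with one nitrogen, three ring bonds from the ring atom that bears a large group. For the measured compounds named here, the one measured step that bears on this change is a 1.2-fold higher number from compound 1 to compound 2 (0.09 log units; within the scatter), which altered the group on the same nitrogen's carbonyl and stayed within the scatter. Compound 3 is therefore expected to differ from compound 2 by no step beyond the scatter, a 1.1-fold higher number from compound 2 to compound 3 (0.04 log units; within the scatter), and its estimated value in this assay is 85 nM, within 35 nM to 200 nM.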

Compound 3, half-maximal effective concentration: 1050 nM
Compound 3: middle estimate off by 12-fold (1.09 log units), on the low side; the whole stated range lies below it.
By their numbers in this assay, from the lowest: compounds 1 and 2 (each within the scatter of the next); then compound 3.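

In this assay, the group on this ring nitrogen proves able to move the number by a large amount: the change gives a 14-fold higher number from compound 2 to compound 3 (1.13 log units; beyond the scatter) and, measured against the other earlier compound, a 17-fold higher number from compound 1 to compound 3 (1.22 log units; beyond the scatter), whereas the difference between those two earlier groups stayed within the scatter. The change alters two features at once, since a carbonyl becomes a thiocarbonyl, with sulfur and oxygen exchanging roles, while the cyclobutyl ring gives way to an isopropyl group. Nothing available here accounts for this rise.

The compounds shown do not separate the contribution of the thiocarbonyl from that of losing the ring. An isopropyl group on an oxygen-linked carbonyl, or a cyclobutyl group on an oxygen-linked thiocarbonyl, would tell these two contributions apart.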